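The source may hold more compounds than are shown below. What is called first, only, known or untested is meant among the compounds shown, and "the series" means these compounds.

Compound 2 `CC(C(=O)NCc1ccc(C(F)(F)F)cc1OCc1ccc(F)cc1)c1ccc(NS(C)(=O)=O)c(F)c1` gives 0.5 nM in an assay on CHO cells for antagonist activity at transient receptor potential cation channel subfamily V member 1 (Homo sapiens), read by FLIPR (on this read-out lower numbers stand for stronger inhibition and higher numbers for weaker inhibition), the lowest of the two numbers recorded there. Among the compounds with values here, its nearest neighbour is compound 1 `CC(C)COc1cc(C(F)(F)F)ccc1CNC(=O)C(C)c1ccc(NS(C)(=O)=O)c(F)c1`, which in this assay gives 0.8 nM; the only measured step, a 1.6-fold lower number from compound 1 to compound 2 (0.20 log units; within the scatter), comes from putting 4-fluorophenyl in place of isopropyl on a saturated chain carbon bound to an oxygen on an aromatic ring. Compound 3 `COc1ccc(-c2cc(C(F)(F)F)ccc2CNC(=O)C(C)c2ccc(NS(C)(=O)=O)c(F)c2)cc1OC` is not yet measured. It differs from compound 2 by 3,4-dimethoxyphenyl in place of (4-fluorobenzyl)oxy on an aromatic carbon, at a position ortho to a large group and meta to a trifluoromethyl group. Within the data shown here, the one measured step varied a substituent hanging from the ether oxygen, whereas here the whole (4-fluorobenzyl)oxy group is exchanged for 3,4-dimethoxyphenyl, so no step bears on it directly. The account therefore expects compound 3 to show a modest weakening, a 4.0-fold higher number from compound 2 to compound 3 (0.60 log units; beyond the scatter), with an estimate of 2 nM and a range from 0.5 nM to 8 nM.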

Compound 3, inhibition constant: 8.6 nM
Compound 3: the middle estimate sits 4.3-fold (0.63 log units) below what was measured; measured number outside the range, above it.
By their numbers in this assay, from the lowest: compounds 2 and 1 (each within the scatter of the next); then compound 3.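

At this position, ortho to a large group and meta to a trifluoromethyl group, isobutoxy and (4-fluorobenzyl)oxy had given values within the scatter of each other in this assay, which could have suggested that the position tolerates change freely. The 3,4-dimethoxyphenyl group shows a limit to that tolerance, with a 17-fold higher number from compound 2 to compound 3 (1.24 log units; beyond the scatter) and an 11-fold higher number from compound 1 to compound 3 (1.03 log units; beyond the scatter), so the group carried here does matter, even though compound 3 remains a single-digit nanomolar inhibitor. No measurement available here accounts for this loss.

The compounds shown leave open whether the weakening goes with the missing ether oxygen or with the two methoxy groups on the ring. An unsubstituted phenyl ring, or a benzylamino group in the same place, would help separate these possibilities.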